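The source may report more compounds than this note shows. Statements on the series, on what has been measured and on what is new or still open speak of the compounds shown alone.

Values so far in a functional assay on HeLa cells (Homo sapiens) for cytotoxicity, read by MTT assay, with a stated time of 48 h; on this read-out lower numbers stand for stronger inhibition and higher numbers for weaker inhibition
compound 1 `O=C(O)CN1C(=O)/C(=C/c2nc3ccccc3n2Cc2ccc(Br)cc2)SC1=S` gives 12900 nM
compound 2 `N#Cc1ccc(Cn2c(/C=C3\SC(=S)N(CC(=O)O)C3=O)nc3ccccc32)cc1` gives 16300 nM
compound 3 `O=C(O)CN1C(=O)/C(=C/c2nc3ccccc3n2Cc2ccccc2)SC1=S` gives 22700 nM

Compound 3 stands at 22700 nM and is not separated from the other two compounds, since all three values lie within the scatter of each other. The next compound is compound 4 `Cc1ccc(Cn2c(/C=C3\SC(=S)N(CC(=O)O)C3=O)nc3ccccc32)cc1`, which has methyl in place of hydrogen on an aromatic carbon, para to a large group (methyl in place of hydrogen on an aromatic carbon). Going by the values given here, no methyl compound has been measured yet, so the closest evidence is the two measured changes at that hydrogen. Compound 1 carries bromo and compound 2 carries cyano there. The steps are a 1.8-fold higher number from compound 1 to compound 3 (0.25 log units; within the scatter) and a 1.4-fold higher number from compound 2 to compound 3 (0.14 log units; within the scatter), and the step between the two substituted compounds is a 1.3-fold higher number from compound 1 to compound 2 (0.10 log units; within the scatter). None of these leaves the scatter, so no step beyond the scatter is expected in this assay, and no direction can be called with confidence. The estimated step is a 1.3-fold lower number from compound 3 to compound 4 (0.10 log units; within the scatter). The expected value for compound 4 is 18000 nM, with an estimated range of 10000 nM to 32000 nM.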

Compound 4, half-maximal inhibitory concentration: 1280 nM
For compound 4 the middle estimate is 14-fold (1.15 log units) above the measured one, and the stated range ends above it.
By their numbers in this assay, from the lowest: compound 4; then compounds 1, 2 and 3 (each within the scatter of the next).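

In this assay, going by these compounds alone, the position that looked flat among the earlier compounds now responds: going from benzyl to 4-methylbenzyl gives an 18-fold lower number from compound 3 to compound 4 (1.25 log units; beyond the scatter), the first step beyond the scatter. Methyl also separates from both other substituents on this aromatic carbon, with a 13-fold lower number from compound 2 to compound 4 (1.10 log units; beyond the scatter) and a 10-fold lower number from compound 1 to compound 4 (1.00 log units; beyond the scatter), whereas bromo, cyano and hydrogen remain within the scatter of each other, so the identity of the group here can matter and, among these four, only methyl stands apart. No available measurement bears on what lies behind this result.

On these data alone, whether the gain is specific to methyl or extends to ethyl, methoxy or a longer chain on this carbon remains open. Also open, as far as these compounds go, is how an amine would behave here, and whether methyl on another carbon of the same ring would give a similar step.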